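Replacing the thiophen-2-yl group: an estimate for compound 4

The source may hold more compounds than are shown below. What is called first, only, known or untested is meant among the compounds shown, and "the series" means these compounds.

Measured so far in a functional assay on MCF7 cells (Homo sapiens) for antiproliferative activity, read by MTT assay, with a stated time of 72 h; a higher number here means a weaker inhibitor, a lower number a stronger inhibitor:
compound 1 `CCCSc1nc(N/N=C/c2ccccc2F)c2nnn(Cc3ccccc3)c2n1` gives > 64000 nM, a limit of the assay.
compound 2 `CCCSc1nc(N/N=C/c2ccccc2Cl)c2nnn(Cc3ccccc3)c2n1` gives 13800 nM.
compound 3 `CCCSc1nc(N/N=C/c2cccs2)c2nnn(Cc3ccccc3)c2n1` gives > 64000 nM, a limit of the assay.

Compound 3 thus stands at the limit of > 64000 nM in this assay, at which 2 of the 3 values shown sit, shared with compound 1, and the step that the two limits leave unreadable from compound 1 to compound 3 cannot be read. Among the compounds with values here, the one readable step is an at least 4.6-fold higher number from compound 2 to compound 3 (0.66 log units; beyond the scatter). Compound 4 `CCCSc1nc(N/N=C(\C)c2ccc(Br)cc2)c2nnn(Cc3ccccc3)c2n1` differs from compound 3 by a group of 10 heavy atoms (8 carbon, 1 nitrogen, 1 bromine; one six-membered aromatic ring of carbon only) in place of a group of 7 heavy atoms (5 carbon, 1 nitrogen, 1 sulfur; one five-membered aromatic ring with 1 hetero atom), on a nitrogen on an aromatic ring. The change goes back toward a six-membered carbon ring carrying a halogen, so a decrease beyond the scatter is expected because an at least 4.6-fold higher number from compound 2 to compound 3 (0.66 log units; beyond the scatter) ran the other way. The step of an at least 3.2-fold lower number from compound 3 to compound 4 (0.50 log units; beyond the scatter) is the expected outcome. Compound 4 is estimated at 20000 nM, within 6000 nM to 64000 nM.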

Compound 4, half-maximal inhibitory concentration: 13000 nM
Estimate against measurement, compound 4: 1.5-fold (0.19 log units) above; the range from low to high includes it.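

In this assay this place on the nitrogen tolerates a bromine-bearing group, with an at least 4.9-fold lower number from compound 3 to compound 4 (0.69 log units; beyond the scatter) and an at least 4.9-fold lower number from compound 1 to compound 4 (0.69 log units; beyond the scatter). Against the chlorine-bearing group of compound 2, the step is a 1.1-fold lower number from compound 2 to compound 4 (0.03 log units; within the scatter), so the two groups are not separated here. Both other steps give only a minimum size, set by a limit of the assay: the limit of > 64000 nM in this assay, at which 2 of the 4 values shown sit.

Whether the halogen alone accounts for the difference stays open, since the fluorine-bearing compound 1 also has a six-membered aromatic ring of carbon only. An amine or a carboxylic acid on that ring remains untested in the compounds shown.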